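The source may hold more compounds than are shown below. What is called first, only, known or untested is meant among the compounds shown, and "the series" means these compounds.

Within the data shown here, compound 2 `COc1c(C)cnc(C[S+]([O-])c2nnc(-c3ccccc3)o2)c1C` is one of only two compounds measured in a functional assay on HUVEC cells (Homo sapiens) for inhibition, read by ELISA (on this read-out higher numbers stand for weaker inhibition and lower numbers for stronger inhibition), where compound 2 gives 6000 nM. Among the measured compounds shown here, the other, compound 1 `CCCc1nnc([S+]([O-])Cc2ncc(C)c(OC)c2C)o1`, gives 8000 nM in this assay, and the single measured step, a 1.3-fold lower number from compound 1 to compound 2 (0.12 log units; within the scatter), lies within the scatter. Compound 3 `COc1c(C)cnc(C[S+]([O-])c2nnc(-c3cccc(F)c3)o2)c1C` differs from compound 2 by fluoro in place of hydrogen on an aromatic carbon. For the measured compounds named here, no measured step involves a fluoro group, and the one step that exists stayed within the scatter, so no movement beyond the scatter is expected in this assay. For compound 3 the estimate is 6000 nM, within a range from 2500 nM to 15000 nM, which means an expected step of no change at the digits printed from compound 2 to compound 3 (within the scatter).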

Compound 3, half-maximal inhibitory concentration: 12000 nM
Estimate against measurement, compound 3: 2.0-fold (0.30 log units) below, within the range that was stated.
By their numbers in this assay, from the lowest: compounds 2, 1 and 3 (each within the scatter of the next).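

Putting fluoro on the phenyl ring gives a 2.0-fold higher number from compound 2 to compound 3 (0.30 log units; within the scatter) in this assay and so adds the first substituent on this ring without leaving the scatter. Replacing propyl with 3-fluorophenyl gives a 1.5-fold higher number from compound 1 to compound 3 (0.18 log units; within the scatter) and likewise stays within it, so propyl, phenyl and 3-fluorophenyl cannot be told apart in this small set. Nothing available explains these numbers.

Going by these compounds, whether an amine or a carboxylic acid on this ring would shift the number beyond the scatter remains open. So does the effect of a longer chain in place of propyl.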